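A few compounds are considered here, and "the series" means these few. Any claim that something is new, unique, unknown or untested is made for them only; others in the source may bear on it.

Measured so far in a functional assay on RAW264.7 cells (Mus musculus) for inhibition, with a stated time of 4 days; a lower number here means a stronger inhibitor, a higher number a weaker inhibitor:
compound 1 `COc1ccc(/C=C/C(=O)c2cccc(N=[N+]=[N-])c2)cc1O`: 1960 nM
compound 2 `COc1ccc(/C=C/C(=O)c2cccc(-n3cc(C(C)(C)O)nn3)c2)cc1O`: 17100 nM

Compound 2 stands highest of the two numbers in this assay; its nearest neighbour is compound 1, the step being an 8.7-fold higher number from compound 1 to compound 2 (0.94 log units; beyond the scatter). Compound 3 `C=C(C)c1cn(-c2cccc(C(=O)/C=C/c3ccc(OC)c(O)c3)c2)nn1` is not yet measured. It differs from compound 2 in one place: 1-methylethenyl in place of 1-hydroxy-1-methylethyl on an aromatic carbon. Within the data shown here, no measured step exchanges these two groups; the only step, an 8.7-fold higher number from compound 1 to compound 2 (0.94 log units; beyond the scatter), changes azido for the whole triazolyl group and gives no direct guide. The step in this assay is therefore expected to be small, a 1.4-fold lower number from compound 2 to compound 3 (0.15 log units; within the scatter), possibly within the scatter. Compound 3 is estimated at 12000 nM, range 4000 nM to 40000 nM.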

Compound 3, half-maximal inhibitory concentration: 7760 nM
Beside the measured number, compound 3's estimate is 1.5-fold (0.19 log units) above it; measured number inside the range.
By their numbers in this assay, from the lowest: compound 1; then compound 3; then compound 2.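

In this assay, the group on this triazole carbon affects the number on its own: 1-methylethenyl in place of 1-hydroxy-1-methylethyl gives a 2.2-fold lower number from compound 2 to compound 3 (0.34 log units; beyond the scatter). The better of these two triazolyl groups still does not recover the azido level, with a 4.0-fold higher number from compound 1 to compound 3 (0.60 log units; beyond the scatter), so compound 1 keeps the lowest number of the three. No measurement offered here explains either step. The pair leaves open whether the step follows the lost hydroxyl or the entering double bond, which a plain isopropyl group would separate. As far as these compounds go, whether an amine, a carboxylic acid or a longer alkyl chain here would reach the level of compound 1 also remains open.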